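Methoxy for Cyano: Cytotoxicity on Mouse Fibroblasts

The source may report more compounds than this note shows. Statements on the series, on what has been measured and on what is new or still open speak of the compounds shown alone.

Compound 1, `C/C(=C\c1cccc(-c2ccccc2)c1)C(N)=O`: > 50000 nM (a limit)
Compound 2, `C/C(=C\c1cc(-c2ccc(C#N)cc2)cs1)C(N)=O`: > 50000 nM (a limit)

In an ADME assay on NIH3T3 cells (Mus musculus) for cytotoxicity, read by CCK-8 assay, with a stated time of 24 h (on this read-out lower numbers stand for stronger inhibition and higher numbers for weaker inhibition), compound 1 gives > 50000 nM, which is a limit of the assay rather than a number. Compound 2 likewise gives > 50000 nM in this assay, again a limit. Compound 2 therefore stands at the limit of > 50000 nM in this assay, at which 2 of the 2 values shown sit, and nothing separates it from compound 1 on the numbers shown. Compound 3, `COc1ccc(-c2csc(/C=C(\C)C(N)=O)c2)cc1`, has not yet been measured in this assay. It differs from compound 2 by methoxy in place of cyano on an aromatic carbon. Within the data shown here, no step between measured compounds is available to size this change; with both measured values sitting at the same limit, the step that the limit leaves unreadable from compound 2 to compound 3 is expected to be none beyond the scatter, most probably ending at a limit once more. Compound 3 is accordingly estimated at 60000 nM, with a range from 30000 nM to 150000 nM.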

Compound 3, half-maximal inhibitory concentration: > 50000 nM
Compound 3: a limit, no number; the forecaster's own chance of this, stated with the estimate: 85%; the middle value lies beyond the limit too.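

The step from compound 2 to compound 3, methoxy in place of cyano, cannot be read, because the values give no number: the limit of > 50000 nM in this assay, at which 3 of the 3 values shown sit.

From the compounds shown here alone, whether methoxy and cyano differ at all in this assay stays open, as does the concentration at which compound 1, compound 2 or compound 3 would reach half-maximal inhibition.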